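Three Anilides at the Assay Limit and a Fourth Expected

This account rests on a few compounds, and the source may have more. Where it says the series, first, only, none or still open, it means among the compounds named here.

Measured compounds:
In a functional assay on NUGC-3 cells (Homo sapiens) for inhibition, read by sulforhodamine B assay, with a stated time of 48 h (on this read-out lower numbers stand for stronger inhibition of growth and higher numbers for weaker inhibition of growth), compound 1, `O=C(Nc1cccc(O)c1)c1nccc2ccccc12`, gives > 10000 nM, which is a limit of the assay and not a number.
In this assay compound 2, `O=C(Nc1ccccc1Cl)c1nccc2ccccc12`, gives > 10000 nM, again a limit of the assay.
In this assay compound 3, `O=C(Nc1cccc(Cl)c1)c1nccc2ccccc12`, gives > 10000 nM, once more a limit of the assay.

Compound 2 and compound 3 are built from the same atoms joined differently; the difference between the two cores is not broken down here. The change from compound 3 to compound 1 is hydroxy in place of chloro on an aromatic carbon, and the step it made, a step that the two limits leave unreadable from compound 3 to compound 1, cannot be read because of the limit of > 10000 nM in this assay, at which 3 of the 3 values shown sit. For compound 2 there is only a limit, as there is for the other two values shown.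

Compound 4, `O=C(Nc1ccccc1O)c1nccc2ccccc12`, has not been measured in this assay. It differs from compound 2 by hydroxy in place of chloro on an aromatic carbon. The change is the same kind as that from compound 3 to compound 1, but the place is not the same: in the measured pair the hydroxy stands meta to a large group, whereas in compound 4 it stands ortho to a large group.

Because (the limit of > 10000 nM in this assay, at which 3 of the 3 values shown sit), the measured step gives no size to carry over, and compound 4 is expected to stay near the limit too. The expected step is a step that the limit leaves unreadable from compound 2 to compound 4. The estimate for compound 4 in this assay is 15000 nM, between 7000 nM and 40000 nM.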

Compound 4, concentration for 50% growth inhibition: > 10000 nM
Compound 4 was reported as a limit; the forecaster's own chance of this, stated with the estimate: 85%; the middle value lies beyond the limit too.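

No new step can be read from compound 2 to compound 4, since each of the two is reported only as a limit of the assay and not as a number: the limit of > 10000 nM in this assay, at which 4 of the 4 values shown sit.

The compounds shown leave open how far any of them lies beyond that limit in this assay and whether hydroxy in place of chloro changes growth inhibition at all, at either place on the ring.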